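The source may hold more compounds than are shown below. What is called first, only, known or untested is meant among the compounds shown, and "the series" means these compounds.

Measured compounds:
compound 1 `CN(C)c1ccc2nc(-c3cccc4ccccc34)[nH]c(=O)c2c1` gives 100%
compound 2 `Cc1cccc(-c2nc3ccc(C)cc3c(=O)[nH]2)c1` gives 75.7%
compound 3 `Cc1ccc2c(=O)[nH]c(-c3ccccc3F)nc2c1` gives 81.2%

In an assay on isolated protein for inhibition of DNA topoisomerase 1 (Homo sapiens), with a stated time of 30 min, tested at 100 uM (a higher number here means a stronger effect of the compound at the concentration tested, a lower number a weaker effect), compound 1 gives the highest of the three numbers. Its nearest neighbour is compound 3, whose value in this assay sits beyond the usual scatter below it, and compound 2 lies further down still, also beyond the scatter. Compound 2, which carries a methyl on the shared core, gives 75.7% in this assay, and compound 3, which also carries a methyl on the shared core, gives 81.2%.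

Compound 4 `Cc1ccc2nc(-c3cccc4ccccc34)[nH]c(=O)c2c1` has yet to be tested in this assay. It differs from compound 1 in one place: methyl in place of dimethylamino on an aromatic carbon. Going by the values given here, no step between measured compounds matches this change. Given that the methyl-bearing compound 2 gives 75.7% and the methyl-bearing compound 3 gives 81.2%, a downward step beyond the scatter is expected for compound 4. For compound 4 the estimated value in this assay is 80% (range 60% to 97%), an expected step of a number 20 percentage points lower from compound 1 to compound 4 (beyond the scatter).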

Compound 4, a percentage reported as inhibition, at one concentration (the size of the read-out at that concentration, not a potency): 4.1%
Estimate against measurement, compound 4: 75.9 percentage points above; measured number outside the range, below it.
By their numbers in this assay, from the lowest: compound 4; then compounds 2 and 3 (each within the scatter of the next); then compound 1.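

In this assay, methyl in place of dimethylamino on this aromatic carbon gives a number 95.9 percentage points lower from compound 1 to compound 4 (beyond the scatter), so with the rest of compound 1 held constant, the read-out depends heavily on the group at this position. The earlier compounds shown here differ from compound 1 in more than one place and could not isolate this change. A methyl on the shared core is thus compatible with both high and very low read-outs.

From the compounds shown here alone, whether the dimethylamino group specifically is required, or whether a primary amine or a methoxy group at this carbon would retain the read-out, remains open. Nothing shown here accounts for the size of this step.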